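Sulfonyl aryl substitution in the quinoxaline-free notes on cytotoxicity

This account rests on a few compounds, and the source may have more. Where it says the series, first, only, none or still open, it means among the compounds named here.

Compound 2 `COc1ccc(S(=O)(=O)c2nc3ccccc3nc2Nc2cc(OC)cc(OC)c2)cc1` gives 13400 nM in a functional assay on HCT-116 cells (Homo sapiens) for cytotoxicity, read by MTT assay, with a stated time of 72 h (on this read-out higher numbers stand for weaker inhibition and lower numbers for stronger inhibition), the highest number of the three measured compounds. Compound 1 `COc1cc(Nc2nc3ccccc3nc2S(=O)(=O)c2ccccc2)cc(OC)c1` gives 950 nM and compound 3 `COc1ccc(S(=O)(=O)c2nc3ccccc3nc2Nc2ccc(F)cc2)cc1` gives 2110 nM; the step of a 14-fold higher number from compound 1 to compound 2 (1.15 log units; beyond the scatter) and the step of a 6.4-fold lower number from compound 2 to compound 3 (0.80 log units; beyond the scatter) both lie beyond the scatter. Compound 4 `COc1cc(Nc2nc3ccccc3nc2S(=O)(=O)c2ccc(Br)cc2)cc(OC)c1` differs from compound 2 by bromo in place of methoxy on an aromatic carbon, para to a large group. For the measured compounds named here, the only measured step at this position is a 14-fold higher number from compound 1 to compound 2 (1.15 log units; beyond the scatter), where methoxy entered in place of hydrogen; the step from compound 2 to compound 3 concerns the other aryl ring and does not bear on it. Going by the values given here, no measured compound carries bromo, so the direction rests only on removal of the methoxy that came with a large rise in number. A lower number than compound 2 is therefore expected, though not necessarily back to compound 1, giving the expected step of a 5.4-fold lower number from compound 2 to compound 4 (0.73 log units; beyond the scatter). Compound 4 is estimated at 2500 nM, in the range 700 nM to 9000 nM.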

Compound 4, half-maximal inhibitory concentration: > 50000 nM
Compound 4: no number, only a limit (the forecaster's own chance of this, stated with the estimate: 5%); middle value at least 20-fold (1.30 log units) from the limit.
By their numbers in this assay, from the lowest: compound 1; then compound 3; then compound 2. At a limit, above all of these: compound 4.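

In this assay compound 4 stands at a limit, not at a number: the limit of > 50000 nM in this assay, at which 1 of the 4 values shown sits. Bromo in place of methoxy gives an at least 3.7-fold higher number from compound 2 to compound 4 (0.57 log units; beyond the scatter), and bromo in place of hydrogen gives an at least 52-fold higher number from compound 1 to compound 4 (1.72 log units; beyond the scatter), so removing the methoxy does not bring the number back towards that of compound 1. The rise seen with methoxy is therefore not specific to that group: among compounds 1, 2 and 4, hydrogen gives the lowest number at this place, para to a large group, and both replacements, with or without a hydrogen-bond acceptor, give a higher one.

Three groups at one place cannot show whether hydrogen is the best substituent there or merely better than methoxy and bromo. An amine or a carboxylic acid at this place remains an open case, as does the same change on the 4-fluorophenyl partner of compound 3.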